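Adding an ethyl group to the side chain of compound 3

The source may report more compounds than this note shows. Statements on the series, on what has been measured and on what is new or still open speak of the compounds shown alone.

Three related compounds have been measured so far in a functional assay on U-87MG ATCC cells (Homo sapiens) for antiproliferative activity; a lower number here means a stronger inhibitor, a higher number a weaker inhibitor. Compound 1 `Cc1c2c(n3c1CCCN(C)[C@@H](C)[C@H](C)Nc1cc-3ccc1C(N)=O)CC(C)(C)CC2=O` gives 133 nM, compound 2 `Cc1c2c(n3c1CCN(C)C[C@@H](C)[C@H](C)Nc1cc-3ccc1C(N)=O)CC(C)(C)CC2=O` gives 49 nM, and compound 3 `Cc1c2c(n3c1CCN(C(=O)CN)C[C@@H](C)[C@H](C)Nc1cc-3ccc1C(N)=O)CC(C)(C)CC2=O` gives 378 nM. Compound 3 therefore has the highest number of the three, which makes it the weakest inhibitor in this small set, and its gap to each of the others is beyond the scatter.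

The next molecule, compound 4 `CC[C@H](N)C(=O)N1CCc2c(C)c3c(n2-c2ccc(C(N)=O)c(c2)N[C@@H](C)[C@H](C)C1)CC(C)(C)CC3=O`, differs from compound 3 at a single place: ethyl in place of hydrogen on a saturated chain carbon bound to an amine nitrogen and a carbonyl carbon. Seen one bond further out, (aminomethyl)carbonyl becomes (1-aminopropyl)carbonyl.

Going by the values given here, only one measured step bears on this change: a 7.7-fold higher number from compound 2 to compound 3 (0.89 log units; beyond the scatter). That step brought in the (aminomethyl)carbonyl group, in place of methyl on an amine nitrogen in a ring, and it was modest in size. Among the compounds with values here, it shows what adding this group did, but not what an ethyl on it will do, since no measured pair tests that change. No direction can be argued from these data, so no shift beyond the scatter is expected in this assay. The expected step is a 1.1-fold higher number from compound 3 to compound 4 (0.05 log units; within the scatter). Compound 4 is estimated at 420 nM, with an expected range of 140 nM to 1250 nM.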

Compound 4, half-maximal inhibitory concentration: 45 nM
For compound 4 the middle estimate is 9.3-fold (0.97 log units) above the measured one; the measured number lies below the stated range.
By their numbers in this assay, from the lowest: compounds 4 and 2 (each within the scatter of the next); then compound 1; then compound 3.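

In this assay, ethyl in place of hydrogen on a saturated chain carbon bound to an amine nitrogen and a carbonyl carbon gives an 8.4-fold lower number from compound 3 to compound 4 (0.92 log units; beyond the scatter) and so has a clear effect, showing that activity in this series is sensitive to this one carbon of the side chain. It also shows that replacing the methyl on the ring amine nitrogen with a larger group need not cost activity: with (1-aminopropyl)carbonyl in that place, the result is a 1.1-fold lower number from compound 2 to compound 4 (0.04 log units; within the scatter) and stays within the scatter, so the weak result of compound 3 belongs to its (aminomethyl)carbonyl group and not to every group of this kind. No measured evidence is available to explain why the ethyl has this effect.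

The compounds shown leave open whether a single methyl on the same carbon would be enough, or whether a longer chain such as butyl or a ring such as cyclopropyl would go further. They also leave open whether the amine on this side chain is needed, which a hydroxyl in its place would test, and how the opposite arrangement at the ethyl-bearing carbon would compare.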